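This account rests on a few compounds, and the source may have more. Where it says the series, first, only, none or still open, it means among the compounds named here.

Measured compounds and their values:

Compound 1 `COc1ccc(/C=N/NC(=O)Nc2ccc(Oc3ccnc(-c4nncn4CCN(C)C)c3)c(F)c2)c(OC)c1` gives 1780 nM in a functional assay on HT-29 cells (Homo sapiens) for cytotoxicity, read by MTT assay, with a stated time of 72 h; a lower number here means a stronger inhibitor, a higher number a weaker inhibitor.
Compound 2 `CN(C)CCn1cnnc1-c1cc(Oc2ccc(NC(=O)N/N=C/c3ccc(O)c(O)c3)cc2F)ccn1` gives 1890 nM in this assay.
Compound 3 `CN(C)CCn1cnnc1-c1cc(Oc2ccc(NC(=O)N/N=C/c3cccc(Cl)c3Cl)cc2F)ccn1` gives 130 nM in this assay.

Compound 3 stands lowest of the three numbers, so it is the strongest inhibitor here: the nearest, compound 1, sits at a 14-fold lower number from compound 1 to compound 3 (1.14 log units; beyond the scatter) in reverse, and compound 2 is further still. The step to compound 4 `CN(C)CCn1cnnc1-c1cc(Oc2ccc(NC(=O)N/N=C/c3ccc(O)cc3O)cc2F)ccn1` changes only the group on the carbon with a double bond to nitrogen: 2,4-dihydroxyphenyl in place of 2,3-dichlorophenyl on a carbon with a double bond to nitrogen. Going by the values given here, two measured steps bear on this, since they change the same group on the same carbon: a 14-fold lower number from compound 1 to compound 3 (1.14 log units; beyond the scatter) and a 15-fold lower number from compound 2 to compound 3 (1.16 log units; beyond the scatter). Both show that moving away from the 2,4-dimethoxyphenyl or 3,4-dihydroxyphenyl to the 2,3-dichlorophenyl brought a large fall in the number, and compound 1 and compound 2 themselves sit within the scatter of each other. Going back from 2,3-dichlorophenyl to a dihydroxyphenyl is therefore expected to raise the number again by a large step, roughly undoing those gains, giving a 12-fold higher number from compound 3 to compound 4 (1.09 log units; beyond the scatter). Compound 4 is thus estimated at 1600 nM, in the range 500 nM to 5000 nM.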

Compound 4, half-maximal inhibitory concentration: 52600 nM
Estimate against measurement, compound 4: 33-fold (1.52 log units) below; measured number above the stated range.
By their numbers in this assay, from the lowest: compound 3; then compounds 1 and 2 (each within the scatter of the next); then compound 4.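

Putting 2,4-dihydroxyphenyl on this carbon gives a 400-fold higher number from compound 3 to compound 4 (2.61 log units; beyond the scatter) in this assay, so this one position spans a far wider range of values than the first three compounds revealed. Two hydroxyl groups on the ring do not give a fixed result: replacing 3,4-dihydroxyphenyl with 2,4-dihydroxyphenyl gives a 28-fold higher number from compound 2 to compound 4 (1.44 log units; beyond the scatter), so their arrangement matters in a way that the close values of compound 1 and compound 2 did not reveal. The ring arrangement alone does not set the value either, since replacing 2,4-dimethoxyphenyl with 2,4-dihydroxyphenyl gives a 30-fold higher number from compound 1 to compound 4 (1.47 log units; beyond the scatter).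

Nothing measured here explains these steps. As far as these compounds go, it also remains open whether a phenyl ring carrying a single chlorine, a single hydroxyl, an amine or a carboxylic acid at this carbon would fall nearer compound 3 or compound 4.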